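Aryl variation on the shared core: nitrile to vinyl

A few compounds are considered here, and "the series" means these few. Any claim that something is new, unique, unknown or untested is made for them only; others in the source may bear on it.

Measured so far in a functional assay on HeLa cells (Homo sapiens) for inhibition, read by CCK-8 assay, with a stated time of 48 h; a lower number here means a stronger inhibitor, a higher number a weaker inhibitor:
compound 1 `COc1cc(-c2ccnc3cc(-c4ccccc4)nn23)cc(OC)c1OC`: 458 nM
compound 2 `COc1cc(-c2ccnc3cc(-c4ccc5cnn(C)c5c4)nn23)cc(OC)c1OC`: 97 nM
compound 3 `COc1cc(-c2ccnc3cc(-c4cccc(C#N)c4)nn23)cc(OC)c1OC`: > 10000 nM

Compound 3 stands at the weak end of the three, and its value is a limit of the assay, not a number; it sits at the limit of > 10000 nM in this assay, at which 1 of the 3 values shown sits. The measured steps are a 4.7-fold lower number from compound 1 to compound 2 (0.67 log units; beyond the scatter), an at least 21-fold higher number from compound 1 to compound 3 (1.33 log units; beyond the scatter) and an at least 100-fold higher number from compound 2 to compound 3 (2.01 log units; beyond the scatter).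

Compound 4 `C=Cc1ccc(-c2cc3nccc(-c4cc(OC)c(OC)c(OC)c4)n3n2)cc1` is the next compound for this assay. It differs from compound 3 in one place: 4-vinylphenyl in place of 3-cyanophenyl on an aromatic carbon. Going by the values given here, the steps that bear on this change are those into compound 3, since both end on the 3-cyanophenyl; the step from compound 1, which carries a plain phenyl, shows that adding cyano to that phenyl moved the value past the limit. Among the compounds with values here, compound 4 removes the cyano and carries instead a vinyl on a phenyl, a group that no measured compound holds. The expectation is that compound 4 returns toward the plain phenyl of compound 1 at 458 nM rather than staying where it stands, so a large step down is expected, an at least 16-fold lower number from compound 3 to compound 4 (1.22 log units; beyond the scatter). Compound 4 is therefore estimated at 600 nM, with a range from 150 nM to 4000 nM.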

Compound 4, half-maximal inhibitory concentration: 882 nM
For compound 4 the middle estimate is 1.5-fold (0.17 log units) below the measured one, within the range that was stated.
By their numbers in this assay, from the lowest: compound 2; then compounds 1 and 4 (each within the scatter of the next). At a limit, above all of these: compound 3.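

In this assay, a substituted phenyl on this aromatic carbon does not in itself lose the activity: 4-vinylphenyl in place of 3-cyanophenyl gives an at least 11-fold lower number from compound 3 to compound 4 (1.05 log units; beyond the scatter). The value of compound 3 is a limit and not a number, so this step has only a lower bound: the limit of > 10000 nM in this assay, at which 1 of the 4 values shown sits. Vinyl in place of hydrogen on the phenyl gives a 1.9-fold higher number from compound 1 to compound 4 (0.28 log units; within the scatter), leaving that pair unseparated, while the bicyclic 1-methyl-1H-indazol-6-yl keeps a clear lead, with a 9.1-fold higher number from compound 2 to compound 4 (0.96 log units; beyond the scatter).

Still open, as far as these compounds go, is whether the result for compound 3 follows the nitrile itself or its place on the phenyl, as 3-cyanophenyl and 4-vinylphenyl differ in both. Also open, from the compounds shown here alone, is how an amine or a carboxylic acid on that phenyl would read in this assay.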